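Pyridyl Limit to Sulfonylphenyl: An Estimate for Compound 3

This account rests on a few compounds, and the source may have more. Where it says the series, first, only, none or still open, it means among the compounds named here.

Compound 1 `CC(C)OC(=O)N1CCC(Oc2ncnc3c2CCN3c2ccc(C#N)cn2)CC1` and compound 2 `CC(C)OC(=O)N1CCC(Oc2ncnc3c2CCN3c2ccc(F)cn2)CC1` share one core and differ only on the aromatic ring attached to it. In a functional assay on CHO-K1 cells for agonist activity at Glucose-dependent insulinotropic receptor (Homo sapiens), read by a luciferase reporter, with a stated time of 5 h (on this read-out lower numbers stand for an effect already at smaller amounts and higher numbers for an effect only at larger amounts of compound), compound 1 gives 794 nM. Compound 2 reaches only the limit of this assay, > 10000 nM. Fluoro in place of cyano on an aromatic carbon thus brought an at least 12-fold higher number from compound 1 to compound 2 (1.10 log units; beyond the scatter), and compound 2 stands at the limit of > 10000 nM in this assay, at which 1 of the 2 values shown sits, with no exact number known for it. Compound 3 `CC(C)OC(=O)N1CCC(Oc2ncnc3c2CCN3c2ccc(S(C)(=O)=O)c(F)c2)CC1` carries 3-fluoro-4-(methylsulfonyl)phenyl in place of 5-fluoropyridin-2-yl on a nitrogen on an aromatic ring in a ring. Within the data shown here, no measured step covers this exchange; the only step in hand, from cyano to fluoro, was large and upward. Because compound 1 with its nitrile gives 794 nM, compound 3 is expected to return to a measurable value, a step estimated as an at least 6.6-fold lower number from compound 2 to compound 3 (0.82 log units; beyond the scatter) in this assay. The estimate for compound 3 is 1500 nM, within 250 nM to 10000 nM.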

Compound 3, half-maximal effective concentration: 158 nM
Compound 3: the middle estimate sits 9.5-fold (0.98 log units) above what was measured; measured number outside the range, below it.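

In this assay, the place on a nitrogen on an aromatic ring in a ring proves able to carry a ring of carbon only: 3-fluoro-4-(methylsulfonyl)phenyl in place of 5-fluoropyridin-2-yl brings an at least 63-fold lower number from compound 2 to compound 3 (1.80 log units; beyond the scatter). The same group in place of 5-cyanopyridin-2-yl brings a 5.0-fold lower number from compound 1 to compound 3 (0.70 log units; beyond the scatter), so among these three compounds a pyridyl ring is not needed for a measurable number, and the nitrile is not the only group that gives one. The first of these steps rests on a limit and gives only a bound: the limit of > 10000 nM in this assay, at which 1 of the 3 values shown sits.

The compounds shown leave open whether the gain belongs to the methylsulfonyl group or to the carbon-only ring, as the two change together. Also open, going by these compounds, is how an amine, a carboxylic acid or a longer chain in place of the methylsulfonyl group would read here.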